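The compounds below may be only part of what the source reports. "The series", "measured", "known", "first", "only" and "open" are said of these compounds alone.

Compound 1 `Cc1ccc(-c2csc(N3N=C(c4ccc(C)s4)CC3c3ccc(F)cc3)n2)cc1`: in a functional assay on A549 cells (Homo sapiens) for antiproliferative activity, read by XTT assay, with a stated time of 24 h (on this read-out lower numbers stand for stronger inhibition and higher numbers for weaker inhibition), compound 1 gives > 500 ug/mL, a limit of the assay.
Compound 2 `Fc1ccc(C2CC(c3ccc(Cl)s3)=NN2c2nc(-c3ccc(C(F)(F)F)cc3)cs2)cc1`: compound 2 gives > 500 ug/mL, likewise a limit.
Compound 3 `Cc1ccc(C2=NN(c3nc(-c4ccc(Br)cc4)cs3)C(c3ccc(F)cc3)C2)s1`: compound 3 gives > 500 ug/mL, again a limit.

Compound 2 thus stands at the limit of > 500 ug/mL in this assay, at which 3 of the 3 values shown sit, with no number attached to it. Compound 4 `N#Cc1ccc(-c2csc(N3N=C(c4ccc(Cl)s4)CC3c3ccc(F)cc3)n2)cc1` differs from compound 2 by cyano in place of trifluoromethyl on an aromatic carbon. Going by the values given here, the only single-point step among the measured compounds, a step that the two limits leave unreadable from compound 1 to compound 3, touches a different position, and its size cannot be read because a step that the two limits leave unreadable from compound 1 to compound 3 runs between two limits. Among the compounds with values here, no measured step therefore bears on the change to compound 4. Compound 4 is expected to remain at or beyond the same limit, the estimated step being a step that the limit leaves unreadable from compound 2 to compound 4. Compound 4 is accordingly estimated at 600 ug/mL, within a range from 150 ug/mL to 2000 ug/mL.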

Compound 4, half-maximal inhibitory concentration: > 500 ug/mL
Compound 4 ended at the assay's limit; the forecaster's own chance of this, stated with the estimate: 80%; the middle value is on the limit's open side.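

In this assay, going by these compounds alone, compound 4 gives > 500 ug/mL, a limit, and compound 2 sits at that same limit, so no step between the two can be read. The compounds shown leave open whether 4-(trifluoromethyl)phenyl and 4-cyanophenyl differ at all in this assay, and what value any of these compounds would have beyond the limit.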